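Arylpiperazine spirooxindole amides: alpha-1 binding notes

The source may hold more compounds than are shown below. What is called first, only, known or untested is meant among the compounds shown, and "the series" means these compounds.

Compounds measured:
- compound 1, `CCC1(CCCCN2CCN(c3ccccc3Cl)CC2)C(=O)Nc2ccccc21`: 64 nM
- compound 2, `CCC1(CCCCN2CCN(c3cccc(C(F)(F)F)c3)CC2)C(=O)Nc2ccccc21`: "not determined" (no result reported)

Going by the values given here, in an assay on membranes from frontal cortex for displacement of a labelled ligand from Adrenergic receptor alpha-1 (Rattus norvegicus), read by scintillation counting, with a stated time of 45 min (a higher number here means a weaker inhibitor, a lower number a stronger inhibitor), compound 1 gives 64 nM, the only number in the set. Compound 2 stands without a result in this assay, so its position relative to compound 1 cannot be stated. Compound 3, `CCC1(CCCCN2CCN(c3ccc(Cl)c(Cl)c3)CC2)C(=O)Nc2ccccc21`, carries 3,4-dichlorophenyl in place of 3-(trifluoromethyl)phenyl on an amine nitrogen in a ring. Among the compounds with values here, with no measured step between any two compounds, the size and direction of this change are unknown from the data; the expectation below rests on compound 1 alone, which shares the core and the linker and differs only in the aryl group on the piperazine nitrogen. Compound 3 is expected near compound 1 in this assay, with a wide range to cover the untested aryl change, estimated at 150 nM (range 40 nM to 600 nM).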

Compound 3, inhibition constant: 125 nM
Compound 3: the middle estimate sits 1.2-fold (0.08 log units) above what was measured, within the range that was stated.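

In this assay, the aryl group on an amine nitrogen in a ring now has its first measured step: 3,4-dichlorophenyl in place of 2-chlorophenyl gives a 2.0-fold higher number from compound 1 to compound 3 (0.29 log units; within the scatter). At this position, this exchange therefore produces no step beyond the scatter, and compound 1 and compound 3 cannot be ranked on this read-out. No measurement shown here bears on why these two aryl groups read alike.

Compound 2 has no result in this assay, so the steps that would place 3-(trifluoromethyl)phenyl against either chlorinated aryl group cannot be read. Also open, on these data alone, is how an unsubstituted phenyl, a methoxyphenyl or a pyridyl group on the same nitrogen would compare, and whether a step beyond the scatter can arise at this position at all.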